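The compounds below may be only part of what the source reports. "The series", "measured", "known", "first", "only" and "open" are said of these compounds alone.

Series notes. Compound 1 `CN1C(=O)COc2cc(Nc3ccc4ncn(CC5CC5)c4n3)cnc21` is the parent of the set; in an ADME assay on microsomes from liver (Homo sapiens) for metabolic stability (a higher number here means that the compound lasts longer, a lower number that the compound disappears faster), compound 1 gives 0.233 h. Compound 2 `Cc1cc(Nc2cnc3c(c2)OCC(=O)N3C)nc2c1ncn2CC1CC1` carries the change methyl in place of hydrogen on an aromatic carbon and in this assay compound 2 gives 0.483 h. That single change made the step of a 2.1-fold higher number from compound 1 to compound 2 (0.32 log units; beyond the scatter). Compound 3 `CN1C(=O)COc2cc(Nc3ncc4ncn(CC5CC5)c4n3)cnc21` sits on a different core; the difference between the core of compound 1 and the core of compound 3 is not broken down here. In this assay compound 3 gives 0.917 h; the values of compound 3 and compound 2 lie within the scatter of each other, while the gap from compound 1 to compound 3 is beyond it.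

Compound 4 `Cc1nc(Nc2cnc3c(c2)OCC(=O)N3C)nc2c1ncn2CC1CC1` is not yet measured. From compound 3 it differs by methyl in place of hydrogen on an aromatic carbon. Against the change made to compound 1, the place here is on a six-membered aromatic ring with 2 nitrogen and next to the ring nitrogen, where the earlier place was on a ring with 1 nitrogen; the change is therefore the same kind of change, not the same. For compound 4 in this assay a step of a 1.7-fold higher number from compound 3 to compound 4 (0.24 log units; within the scatter) is expected. Among the measured compounds shown here, that expectation rests on the step of a 2.1-fold higher number from compound 1 to compound 2 (0.32 log units; beyond the scatter), the only precedent in the set. For the measured compounds named here, the differing surroundings of the place, and the single precedent, widen the range. The estimate for compound 4 is 1.6 h, expected to fall between 0.7 h and 3.5 h.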

Compound 4, half-life: > 1.66 h
Compound 4 gave a limit, no number; the forecaster's own chance of this, stated with the estimate: 5%; middle value at least 1.0-fold (0.01 log units) away from the limit.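

In this assay, compound 4 gives > 1.66 h, which is a limit of the assay and not a number. Going by these compounds, on the core of compound 3, methyl in place of hydrogen on an aromatic carbon gives an at least 1.8-fold higher number from compound 3 to compound 4 (0.25 log units; that floor lies within the scatter), so the direction seen on the core of compound 1 appears again, but only as a floor, and the true size of this step remains unknown. The direction is shared by both cores shown, which is too little to make a rule for the series, and the two steps cannot be said to match or differ in size: the same change on two cores in this assay, a 2.1-fold higher number (0.32 log units; beyond the scatter) from compound 1 to compound 2 and an at least 1.8-fold higher number (0.25 log units; that floor lies within the scatter) from compound 3 to compound 4; the limit leaves it open whether they differ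

On these data alone, without a number for compound 4, the full size of the gain on this core stays open, as does whether a group other than methyl on the same aromatic carbon, such as an amine or a longer chain, would shift the half-life in the same direction. Also open is whether the change would carry over to any core beyond the two shown, and the compounds shown do not reveal where on these structures the loss in this assay takes place.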